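Adding Four Carbons to the Chain of Compound 1

The compounds below may be only part of what the source reports. "The series", "measured", "known", "first", "only" and "open" are said of these compounds alone.

Among the measured compounds shown here, compound 1 `CCCCCCCCCCCCCCNc1nc(=O)c2ncn([C@@H]3O[C@H](CO)[C@@H](O)[C@H]3O)c2c(=O)[nH]1` is the only compound here with a measured number in an assay on isolated protein for inhibition of ATP-dependent RNA helicase SUPV3L1, mitochondrial (Homo sapiens); a higher number here means a weaker inhibitor, a lower number a stronger inhibitor: compound 1 gives 30 ug/mL. The two companions show only limits. Compound 2 `CCCCCCCCCCCCNc1nc(=O)c2c(ncn2[C@H]2C[C@H](O)[C@@H](CO)O2)c(=O)[nH]1`, which carries a different saturated chain on a different sugar, gives > 500 ug/mL in this assay, a limit of the assay rather than a number. Compound 3 `O=c1nc(Nc2ccccc2)[nH]c(=O)c2c1ncn2C1O[C@H](CO)[C@@H](O)[C@H]1O`, with a phenyl group in place of a saturated chain, gives > 500 ug/mL in this assay, again a limit. Compound 1 therefore stands alone with a number, and the limit of > 500 ug/mL in this assay, at which 2 of the 3 values shown sit, marks where the other two sit.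

Compound 4 `CCCCCCCCCCCCCCCCCCNc1nc(=O)c2ncn([C@@H]3O[C@H](CO)[C@@H](O)[C@H]3O)c2c(=O)[nH]1` is not yet measured. It differs from compound 1 by butyl in place of hydrogen on a saturated chain carbon, ten or more bonds along the chain from a nitrogen on an aromatic ring. For the measured compounds named here, no pair of measured compounds differs in just this one place, so no measured step shows how large such a change is. The shared core and the sugar of compound 1 stay the same; only the saturated chain grows, at the place the difference names. The expectation is that the step from compound 1 to compound 4 amounts to a 1.2-fold lower number from compound 1 to compound 4 (0.08 log units; within the scatter), a change no larger than the usual scatter and with no certain direction. Compound 4 is thus expected to give about 25 ug/mL in this assay, estimated to lie between 6 ug/mL and 150 ug/mL.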

Compound 4, half-maximal inhibitory concentration: 30 ug/mL
The estimate for compound 4 lay 1.2-fold (0.08 log units) below the measured number; measured number inside the range.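

In this assay, butyl in place of hydrogen on a saturated chain carbon, ten or more bonds along the chain from a nitrogen on an aromatic ring, gives no change at the digits printed from compound 1 to compound 4 (within the scatter). Before this pair, no two measured compounds differed at this place, so the size of such a change could not be read; now one example shows that these added carbons leave the number within the usual scatter. Nothing measured here explains why the number stays level.

This single step says nothing about what other groups would do at the same place, so a chain carrying an amine or a carboxylic acid at this position, or a longer chain than that of compound 4, could behave quite differently. Nor does it show how short the saturated chain can become on the sugar and core shared by compound 1 and compound 4, and an octyl chain on that same scaffold would begin to test this.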